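The source may report more compounds than this note shows. Statements on the series, on what has been measured and on what is new or still open speak of the compounds shown alone.

Working notes on the series. Three hydantoin-derived compounds have been run in a functional assay on the whole organism (strain CD1) with Mus musculus as the target, in the maximal electroshock model, with a stated time of 4 h; a higher number here means that more compound is needed for the effect, a lower number that less compound is needed. Compound 1 `O=C1NC(c2ccccc2)(c2ccccc2)C(=O)N1CN1CCN(c2cccc(Cl)c2)CC1` gives 100 mg/kg. Compound 2 `CC(C)C1(C(C)C)NC(=O)N(CN2CCN(c3ccc(F)cc3)CC2)C1=O` gives 100 mg/kg. Compound 3 `O=C1NC(c2ccccc2)(c2ccccc2)C(=O)N1CN1CCN(c2ccc(F)cc2)CC1` gives 100 mg/kg. All three therefore sit at the same dose at the digits recorded, within the scatter of one another.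

Compounds 3 and 1 differ in one place: 3-chlorophenyl in place of 4-fluorophenyl on an amine nitrogen in a ring. The step in this assay is no change at the digits printed from compound 3 to compound 1 (within the scatter). Compounds 2 and 3 differ in more than one place; the difference between the two cores is not broken down here, and compound 2 stands level with both compound 1 and compound 3 in this assay.

Compound 4 `CC(C)C1(C(C)C)NC(=O)N(CN2CCN(c3cccc(Cl)c3)CC2)C1=O` has not yet been run. It differs from compound 2 in one place: 3-chlorophenyl in place of 4-fluorophenyl on an amine nitrogen in a ring. The place description for this change matches that of the change from compound 3 to compound 1 word for word, so it is the same change made on the core of compound 2.

For compound 4 in this assay the expected step is no change at the digits printed from compound 2 to compound 4 (within the scatter), beside the earlier one, because no change at the digits printed from compound 3 to compound 1 (within the scatter) and because compound 2 already gives 100 mg/kg. The estimate for compound 4 is 100 mg/kg, expected to lie between 30 mg/kg and 300 mg/kg, resting on a single pair and so held loosely.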

Compound 4, minimum effective dose: 100 mg/kg
Compound 4: the middle estimate sits on the measured number at the digits printed, within the range that was stated.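

The step in this assay is no change at the digits printed from compound 2 to compound 4 (within the scatter) and it matches the step for the same change on the core of compound 3: the same change on two cores in this assay, no change at the digits printed (within the scatter) from compound 3 to compound 1 and no change at the digits printed (within the scatter) from compound 2 to compound 4, 1.0-fold (0.00 log units) apart, within the scatter of two such steps

Within these two pairs, then, putting 3-chlorophenyl in place of 4-fluorophenyl on an amine nitrogen in a ring reads the same on both cores, and neither pair shows a shift. This does not show that the change carries a transferable effect of any size: both steps lie within the scatter, so their agreement says nothing about how a step beyond the scatter would travel from one core to another, and two pairs make no rule for cores outside them.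

All four compounds stand level at the digits printed, so the compounds shown do not reveal which part of the structure, if any, moves this read-out. Open, going by these compounds, is whether a methoxy group or a nitrile on the phenyl ring in place of these halogens, or a longer chain in place of the link from the core to the ring nitrogen, would give a step beyond the scatter in this assay on either core.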